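Adding a second pentan-3-yl group to compound 2

The source may hold more compounds than are shown below. What is called first, only, known or untested is meant among the compounds shown, and "the series" means these compounds.

In a functional assay on HT-22 cells (Mus musculus), read by MTT assay, with a stated time of 24 h (on this read-out higher numbers stand for an effect only at larger amounts of compound and lower numbers for an effect already at smaller amounts), compound 1 (`CC(C)(C)c1cc(/C=C/c2cc(O)cc(O)c2)ccc1O`) gives 484 nM and compound 2 (`CCC(CC)c1cc(/C=C/C=C/c2cc(O)cc(O)c2)ccc1O`) gives 79 nM, the lower of the two numbers, with the gap beyond the usual scatter. Compound 3 (`CCC(CC)c1cc(/C=C/C=C/c2cc(O)cc(O)c2)cc(C(CC)CC)c1O`) differs from compound 2 by pentan-3-yl in place of hydrogen on an aromatic carbon, ortho to a hydroxy group (pentan-3-yl in place of hydrogen on an aromatic carbon). Within the data shown here, no measured pair covers this change. In this assay no step beyond the scatter is expected, with a slight lean towards lower numbers (a 1.6-fold lower number from compound 2 to compound 3 (0.20 log units; within the scatter)). For compound 3 the estimated value is 50 nM (range 12 nM to 200 nM).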

Compound 3, half-maximal effective concentration: 12 nM
The estimate for compound 3 lay 4.2-fold (0.62 log units) above the measured number; low and high end bracket the measured number.
By their numbers in this assay, from the lowest: compound 3; then compound 2; then compound 1.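

In this assay, among these compounds, pentan-3-yl in place of hydrogen on the aromatic carbon ortho to a hydroxy group gives a 6.6-fold lower number from compound 2 to compound 3 (0.82 log units; beyond the scatter) as the first one-place step. This position is therefore not indifferent to substitution: a second pentan-3-yl group goes with an effect at smaller amounts of compound. Nothing measured here accounts for the step. Still open, on these data alone, is whether methyl, an amine or a carboxylic acid at this position would move the number the same way, and whether the step carries over to the core of compound 1.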